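The source may report more compounds than this note shows. Statements on the series, on what has been measured and on what is new or still open speak of the compounds shown alone.

Compound 3 `O=C1Nc2ccc(C(=O)N3CCCC3)cc2/C1=C/c1cc(Cl)c(O)c(Cl)c1` gives -10% in an assay on HeLa cells for inhibition of Kinesin-like protein KIF15 (Homo sapiens), read by microscopy, with stated times of 2 s and 20 s, tested at 750 nM (a higher number here means more inhibition at the concentration tested (going by the name of the read-out), a lower number less inhibition), the lowest of the three numbers shown; compound 2 `O=C1Nc2ccc(C(=O)c3ccco3)cc2/C1=C/c1ccnc(Cl)c1` gives 15.8% and compound 1 `O=C1Nc2ccc(C(=O)c3ccco3)cc2/C1=C/c1cc(Cl)c(O)c(Br)c1` gives 62%. Compound 4 `O=C1Nc2ccc(-c3cccc(F)c3)cc2/C1=C/c1cc(Cl)c(O)c(Cl)c1` differs from compound 3 by 3-fluorophenyl in place of (pyrrolidin-1-yl)carbonyl on an aromatic carbon. No measured step bears directly on this position: the one step shown, a number 46.2 percentage points lower from compound 1 to compound 2 (beyond the scatter), concerns the other aryl group, and compound 1 and compound 3 differ in two places, so their values can only be set side by side. The size of the step is therefore uncertain, and an increase beyond the scatter is thought likelier than none, so the estimated step is a number 40 percentage points higher from compound 3 to compound 4 (beyond the scatter). Compound 4 is estimated at 30%, within a range from -10% to 65%.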

Compound 4, a percentage reported as inhibition, at one concentration (the size of the read-out at that concentration, not a potency): -5.8%
Beside the measured number, compound 4's estimate is 35.8 percentage points above it, and the stated range covers the measured number.
By their numbers in this assay, from the lowest: compounds 3 and 4 (each within the scatter of the next); then compound 2; then compound 1.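

In this assay, within the data shown here, the first measured step at this aromatic carbon is a number 4.2 percentage points higher from compound 3 to compound 4 (within the scatter). With the rest of compound 3 kept, 3-fluorophenyl and (pyrrolidin-1-yl)carbonyl therefore cannot be told apart, even though the two groups share no ring type and only the latter carries a hydrogen-bond acceptor. Nothing on hand accounts for this result.

Still open, as far as these compounds go, is whether any group on this carbon raises the number while the other aryl group stays as in compound 3. An aminomethyl group or a carboxylic acid here would test that.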